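Fluoro removal on the benzyl group across two cores

The source may hold more compounds than are shown below. What is called first, only, known or untested is meant among the compounds shown, and "the series" means these compounds.

Compound 1 `C=C(Br)C(=O)Nc1ccc(/C=C2\SC(=O)N(Cc3ccccc3)C2=O)cc1` and compound 2 `C=C(Br)C(=O)Nc1ccc(/C=C2\SC(=O)N(Cc3ccc(F)cc3)C2=O)cc1` share one core; compound 3 `C=C(Br)C(=O)Nc1cccc(/C=C2\SC(=O)N(Cc3ccc(F)cc3)C2=O)c1` is built on the other core, and the difference between the two cores is not broken down here. In a functional assay on L1210 cells (Mus musculus) for cytotoxicity, read by cell counting, with a stated time of 2 days (on this read-out higher numbers stand for weaker inhibition and lower numbers for stronger inhibition), compound 1 gives 1100 nM and compound 2 gives 2200 nM; the step of a 2.0-fold lower number from compound 2 to compound 1 (0.30 log units; within the scatter) corresponds to the change (hydrogen in place of fluoro on an aromatic carbon). In this assay compound 3 gives 680 nM; against compound 1 it lies within the scatter, against compound 2 beyond it. Compound 4 `C=C(Br)C(=O)Nc1cccc(/C=C2\SC(=O)N(Cc3ccccc3)C2=O)c1` is not yet measured. It differs from compound 3 by hydrogen in place of fluoro on an aromatic carbon, the same change as from compound 2 to compound 1, at the same kind of place, and this is the second time the change appears in the series. Among the measured compounds shown here, since the one measured instance of it gave a step within the scatter, for compound 4 in this assay a step of about a 1.5-fold lower number from compound 3 to compound 4 (0.18 log units; within the scatter) is expected, resting only on the single step of a 2.0-fold lower number from compound 2 to compound 1 (0.30 log units; within the scatter) and carrying its uncertainty. The expected value for compound 4 in this assay is 450 nM, with a likely range from 200 nM to 1000 nM.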

Compound 4, half-maximal inhibitory concentration: 380 nM
Compound 4: the middle estimate sits 1.2-fold (0.07 log units) above what was measured; low and high end bracket the measured number.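

On the second core, 4-fluorobenzyl to benzyl in this assay gives a 1.8-fold lower number from compound 3 to compound 4 (0.25 log units; within the scatter), and this step matches the one seen on the first core: the same change on two cores in this assay, a 2.0-fold lower number (0.30 log units; within the scatter) from compound 2 to compound 1 and a 1.8-fold lower number (0.25 log units; within the scatter) from compound 3 to compound 4, 1.1-fold (0.05 log units) apart, within the scatter of two such steps As far as these two cores go, the change carries over with no detectable dependence on the core, and the step on one core would have served as a fair guide to the step on the other. Among the compounds shown here, it does not show that the change itself has an effect, since each step lies within the scatter and a small shared step cannot be told apart from no step at all; nor does a single pair of cores support a rule for the series as a whole.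

The compounds shown carry only fluoro or hydrogen at this place on the benzyl group, which leaves open what chloro, methoxy, an amine or a carboxylic acid there would do in this assay. Also open, going by these compounds, is whether the agreement between cores would hold for a larger step, such as one from replacing the benzyl group with a longer chain.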